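A few compounds are considered here, and "the series" means these few. Any claim that something is new, unique, unknown or untested is made for them only; others in the source may bear on it.

Measured so far in a functional assay on the whole organism (Tail, strain ICR) with Mus musculus as the target, in the tail flick test, with a stated time of 30 min, at a dose of 25 umol/kg by the oral route; on this read-out higher numbers stand for a stronger effect at the one dose given and lower numbers for a weaker effect:
- compound 1 `C[C@@H](O)[C@H](NC(=O)CN(c1nc(Cl)nc2[nH]cnc12)C1CC1)C(=O)O` — 18.6%
- compound 2 `O=C(O)C[C@H](NC(=O)CN(c1nc(Cl)nc2[nH]cnc12)C1CC1)C(=O)O` — 19.9%

The two numbers lie within the scatter of each other, so compound 2 is not distinguished from compound 1 on this read-out. Among the compounds with values here, the one step available is a number 1.3 percentage points higher from compound 1 to compound 2 (within the scatter): exchange of the side chain on the saturated chain carbon left the response where it was.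

Compound 3 `CSCC[C@H](NC(=O)CN(c1nc(Cl)nc2[nH]cnc12)C1CC1)C(=O)O` is unmeasured. Against compound 2 the change is (methylsulfanyl)methyl in place of carboxy on a saturated chain carbon, two bonds along the chain from an amide-type nitrogen and a carbonyl carbon. Within the data shown here, the only step that bears on it is the one from compound 1 to compound 2, which also altered the side chain on the same chain carbon and produced nothing beyond the scatter. Compound 3 removes the carboxy and brings in a (methylsulfanyl)methyl, a change of the same kind at the same place, so no step beyond the scatter is expected in this assay in either direction; with one precedent only, the range is kept wide.

Compound 3 is therefore expected to give 20%, between 8% and 34%. That corresponds to an expected step of a number 0.1 percentage points higher from compound 2 to compound 3 (within the scatter).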

Compound 3, a percentage reported as activity, at one dose (the size of the read-out at that dose, not a potency): 20.4%
The estimate for compound 3 lay 0.4 percentage points below the measured number; the range from low to high includes it.
By their numbers in this assay, from the lowest: compounds 1, 2 and 3 (each within the scatter of the next).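

In this assay, the step of a number 0.5 percentage points higher from compound 2 to compound 3 (within the scatter) shows that, on a saturated chain carbon, two bonds along the chain from an amide-type nitrogen and a carbonyl carbon, carboxy can give way to (methylsulfanyl)methyl without a separable change in response at this one dose. This exchange goes further than the earlier one: the carboxy leaves with its hydrogen-bond donor, and the group that enters has no donor and brings in sulfur, so this read-out does not depend on a side-chain carboxy in these compounds, and the step of a number 1.8 percentage points higher from compound 1 to compound 3 (within the scatter) shows the same for 2-(methylsulfanyl)ethyl against 1-hydroxyethyl. No measurement is available that bears on why the response stays level across these side chains.

From the compounds shown here alone, whether an amine, such as a 4-aminobutyl side chain, or a benzyl group on the same carbon would move the response beyond the scatter remains open, as does the effect of a longer chain carrying the sulfur. With a single oral dose and a single time point, the compounds also leave open whether these side chains would separate at other doses or times.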